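This account rests on a few compounds, and the source may have more. Where it says the series, first, only, none or still open, it means among the compounds named here.

Compound 3 `O=C(Nc1ccc(Cl)c(-c2nnc3c(Cl)cccn23)c1)c1ccon1` is known in a functional assay on MCF7 cells (Homo sapiens) for antiproliferative activity, read by MTT assay, with a stated time of 72 h (a lower number here means a stronger inhibitor, a higher number a weaker inhibitor), only as a limit, > 100000 nM. Of its two neighbours, compound 1 `O=C(Nc1ccc(Cl)c(-c2nnc3c(Cl)cccn23)c1)c1ccccn1` gives 96400 nM in this assay. Compound 2 `Cc1nc(C(=O)Nc2ccc(Cl)c(-c3nnc4c(Cl)cccn34)c2)cs1` is recorded only as a limit as well, > 100000 nM. Accordingly the steps of an at least 1.0-fold higher number from compound 1 to compound 3 (0.01 log units; that floor lies within the scatter) and an at least 1.0-fold higher number from compound 1 to compound 2 (0.01 log units; that floor lies within the scatter) show only a floor, and a step that the two limits leave unreadable from compound 2 to compound 3; all three values sit at or next to the limit of > 100000 nM in this assay, at which 2 of the 3 values shown sit. Compound 4 `CS(=O)(=O)c1cccc(C(=O)Nc2ccc(Cl)c(-c3nnc4c(Cl)cccn34)c2)c1` differs from compound 3 by 3-(methylsulfonyl)phenyl in place of 1,2-oxazol-3-yl on a carbonyl carbon. For the measured compounds named here, no measured step covers this group, and every measured step is either within the scatter or unreadable, so no shift beyond the scatter is expected in this assay. Compound 4 is therefore expected near 90000 nM, between 30000 nM and 300000 nM, which would amount to an expected at least 1.1-fold lower number from compound 3 to compound 4 (0.04 log units; that floor lies within the scatter).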

Compound 4, half-maximal inhibitory concentration: 88900 nM
For compound 4 the middle estimate is 1.0-fold (0.01 log units) above the measured one, and the stated range covers the measured number.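

Swapping in the larger 3-(methylsulfonyl)phenyl, a ring of carbon only, does not move the result in this assay beyond the scatter, as the one fully readable comparison gives a 1.1-fold lower number from compound 1 to compound 4 (0.04 log units; within the scatter). The other two comparisons give only floors, an at least 1.1-fold lower number from compound 3 to compound 4 (0.05 log units; that floor lies within the scatter) and an at least 1.1-fold lower number from compound 2 to compound 4 (0.05 log units; that floor lies within the scatter), and these are floors because one end of each step is a limit: the limit of > 100000 nM in this assay, at which 2 of the 4 values shown sit.

Going by these compounds, whether any group on this carbonyl carbon can give a value far from that limit stays open. All groups shown are aromatic rings, so an amine, a carboxylic acid or an open alkyl chain here remains untested among these compounds.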